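Adding a second ring chloro to compound 2

This account rests on a few compounds, and the source may have more. Where it says the series, first, only, none or still open, it means among the compounds named here.

Of the compounds shown here, three of the shared core have been read in a functional assay on DU-145 cells (Homo sapiens) for cytotoxicity, read by sulforhodamine B assay, with a stated time of 48 h; a higher number here means a weaker inhibitor of growth, a lower number a stronger inhibitor of growth. Compound 1 `ClCc1cccc(Cn2cnc3ncnc(Cl)c32)c1` gives 15100 nM in this assay. Compound 2 `ClCc1ccccc1Cn1cnc2ncnc(Cl)c21` gives 2950 nM in this assay, which places it second highest of the three numbers: its nearest neighbour is compound 1, whose number is higher by a margin beyond the scatter, and the furthest is compound 3, whose number is lower by a margin also beyond the scatter. Compound 3 `ClCc1cccc(Cn2cnc3nc(Cl)nc(Cl)c32)c1` gives 140 nM in this assay.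

Within the data shown here, the only single-point step known so far is a 110-fold lower number from compound 1 to compound 3 (2.03 log units; beyond the scatter), and it is the very change now proposed for compound 2. Compound 4 `ClCc1ccccc1Cn1cnc2nc(Cl)nc(Cl)c21` is the not yet measured analogue; it differs from compound 2 by chloro in place of hydrogen on an aromatic carbon, the same substitution that carried compound 1 to compound 3.

Among the measured compounds shown here, on that basis a large step downward in this assay is expected, in the direction of a stronger inhibitor of growth, because the one measured precedent a 110-fold lower number from compound 1 to compound 3 (2.03 log units; beyond the scatter) was itself large. For compound 4 the expected value is 35 nM, with a range from 8 nM to 150 nM. This expectation corresponds to a step of an 84-fold lower number from compound 2 to compound 4 (1.93 log units; beyond the scatter), not assumed to reproduce the precedent exactly.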

Compound 4, concentration for 50% growth inhibition: 5490 nM
The estimate for compound 4 lay 160-fold (2.20 log units) below the measured number; measured number outside the range, above it.
By their numbers in this assay, from the lowest: compound 3; then compounds 2 and 4 (each within the scatter of the next); then compound 1.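

In this assay the step is a 1.9-fold higher number from compound 2 to compound 4 (0.27 log units; within the scatter), so chloro in place of hydrogen on the aromatic carbon between two ring nitrogen atoms does not by itself lower the number on the core of compound 2. The large step seen earlier therefore does not carry over from one core to the other, and the outcome of this change at this position depends on the core that carries it: the same change on two cores in this assay, a 110-fold lower number (2.03 log units; beyond the scatter) from compound 1 to compound 3 and a 1.9-fold higher number (0.27 log units; within the scatter) from compound 2 to compound 4, 200-fold (2.30 log units) apart, beyond the scatter of two such steps. Among these compounds, this dependence rests on only two pairs, and within them the large step belongs to the pair of compound 1 and compound 3 alone.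

The compounds shown do not tell which feature of the two cores separates the two pairs. Nor do they tell whether an amine or a methoxy group on that same aromatic carbon would follow the course of chloro on either core.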